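This account rests on a few compounds, and the source may have more. Where it says the series, first, only, none or still open, it means among the compounds named here.

Compound 1 `CCOC(=O)[C@H](CCC(=O)O)NC(=O)c1ccc(CNc2nc3cc(N)cc(N)c3nc2-c2ccccc2)cc1`: < 100000 nM
Compound 2 `Nc1cc(N)c2nc(-c3ccccc3)c(NCc3ccc(Cl)c(Cl)c3)nc2c1`: < 100000 nM

In a functional assay on CAKI-1 cells (Homo sapiens) for inhibition, read by sulforhodamine B assay, with a stated time of 48 h (a lower number here means that less compound is tolerated, a higher number that more compound is tolerated), compound 1 gives only a limit, < 100000 nM. Compound 2 likewise gives only a limit in this assay, < 100000 nM. Both measured values sit at that limit (the limit of < 100000 nM in this assay, at which 2 of the 2 values shown sit), so compound 2 cannot be placed above or below compound 1 on the numbers at hand. Compound 3 `COc1ccc(CNc2nc3cc(N)cc(N)c3nc2-c2ccccc2)cc1OC` differs from compound 2 by 3,4-dimethoxyphenyl in place of 3,4-dichlorophenyl on a saturated chain carbon bound to a nitrogen on an aromatic ring. Among the compounds with values here, no step between measured compounds is available to size this change, and the step that the limit leaves unreadable from compound 2 to compound 3 is expected to stay within the usual scatter. Compound 3 is therefore expected to give about 60000 nM, in a range from 10000 nM to 100000 nM, most likely reported once more only as a limit.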

Compound 3, concentration lethal to 50% of the cells: 53700 nM
For compound 3 the middle estimate is 1.1-fold (0.05 log units) above the measured one; measured number inside the range.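

No size can be given for the change from compound 2 to compound 3, because compound 2 has only a limit: the limit of < 100000 nM in this assay, at which 2 of the 3 values shown sit. The compounds shown leave open whether 3,4-dimethoxyphenyl in place of 3,4-dichlorophenyl shifts the result in this assay at all.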